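From methylpyrazolyl to methoxyphenyl on the shared core

The compounds below may be only part of what the source reports. "The series", "measured", "known", "first", "only" and "open" are said of these compounds alone.

Three compounds were tested in a functional assay on HeLa cells (Homo sapiens) for antiproliferative activity, read by MTT assay, with a stated time of 72 h (a higher number here means a weaker inhibitor, a lower number a stronger inhibitor), with these results.
Compound 1 `C=CC(=O)Nc1cccc(Oc2nc(Nc3ccn(C)n3)nc3c2CSCC3)c1` gives 25800 nM as a measured number
Compound 2 `CC(C)=CC(=O)Nc1cccc(Oc2nc(Nc3ccn(C)n3)nc3c2CSCC3)c1` gives > 50000 nM as a limit
Compound 3 `C=C(C)C(=O)Nc1cccc(Oc2nc(Nc3ccn(C)n3)nc3c2CSCC3)c1` gives > 50000 nM as a limit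

Within the data shown here, compound 1 holds the only true number here. Compounds 2 and 3 stand at the limit of > 50000 nM in this assay, at which 2 of the 3 values shown sit, without a number.

Compound 4 `C=CC(=O)Nc1cccc(Oc2nc(Nc3cccc(OC)c3)nc3c2CSCC3)c1` differs from compound 1 by 3-methoxyphenyl in place of 1-methyl-1H-pyrazol-3-yl on a nitrogen on an aromatic ring on the shared core.

The steps of an at least 1.9-fold higher number from compound 1 to compound 2 (0.28 log units; that floor lies within the scatter) and an at least 1.9-fold higher number from compound 1 to compound 3 (0.28 log units; that floor lies within the scatter) alter only the group on the carbonyl carbon. Neither reaches the group on the nitrogen, so neither gives a size for this change, and no step beyond the scatter is expected in this assay in either direction. The estimate therefore takes compound 1 at 25800 nM as its anchor. Compound 4 is expected at 22000 nM with an estimated range from 7000 nM to 50000 nM in this test. That estimate means a 1.2-fold lower number from compound 1 to compound 4 (0.07 log units; within the scatter) as the expected step.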

Compound 4, half-maximal inhibitory concentration: 28900 nM
For compound 4 the middle estimate is 1.3-fold (0.12 log units) below the measured one; the measured number falls inside the stated range.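

In this assay, among these compounds, the change from 1-methyl-1H-pyrazol-3-yl to 3-methoxyphenyl on the nitrogen gives a 1.1-fold higher number from compound 1 to compound 4 (0.05 log units; within the scatter) and is the first reading at this position, since the earlier steps altered only the group on the carbonyl carbon. Here a six-membered aromatic ring of carbon only reads the same as a five-membered aromatic ring with 2 hetero atoms. Nothing shown bears on why the two groups read alike.

Going by these compounds, whether an amine or a carboxylic acid on this phenyl ring, or a longer chain on the nitrogen, would move the number beyond the scatter remains open.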